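A few compounds are considered here, and "the series" means these few. Any claim that something is new, unique, unknown or untested is made for them only; others in the source may bear on it.

Of the compounds shown here, three have been measured in an assay on CHO cells for displacement of a labelled ligand from adenosine receptor A3 (Homo sapiens), read by scintillation counting, with a stated time of 120 min, tested at 10 uM; on this read-out lower numbers stand for less inhibition and higher numbers for more inhibition at the one concentration tested (going by the name of the read-out). Compound 1 `Nc1scc(CN2CCN(c3cccc(Cl)c3Cl)CC2)c1C(=O)c1ccc(Cl)cc1` gives 0%; compound 2 `Nc1scc(CN2CCN(c3ccncc3)CC2)c1C(=O)c1ccc(Cl)cc1` gives 2%; compound 3 `Nc1scc(CN2CCN(c3cc(F)cc(F)c3)CC2)c1C(=O)c1ccc(Cl)cc1` gives 2%. The steps between them are a number 2 percentage points higher from compound 1 to compound 2 (within the scatter), a number 2 percentage points higher from compound 1 to compound 3 (within the scatter) and no change at the digits printed from compound 2 to compound 3 (within the scatter), so each exchange of the group on the amine nitrogen in a ring has left the read-out unmoved. Compound 3 stands level with compound 2 at the digits shown, and both sit a step within the scatter from compound 1; all three read-outs lie close to the bottom of the scale.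

Compound 4 `Nc1scc(CN2CCN(c3c(F)cc(F)cc3F)CC2)c1C(=O)c1ccc(Cl)cc1` differs from compound 3 in one place: 2,4,6-trifluorophenyl in place of 3,5-difluorophenyl on an amine nitrogen in a ring. Within the data shown here, the steps that bear on it are the three exchanges at the same amine nitrogen in a ring, none of which moved the number beyond the scatter; a step from a difluorophenyl to a trifluorophenyl has not been measured. The expected step is therefore no change at the digits printed from compound 3 to compound 4 (within the scatter), nothing beyond the scatter. Compound 4 is expected to give 2% in this assay, within -6% to 12%.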

Compound 4, a percentage reported as inhibition, at one concentration (the size of the read-out at that concentration, not a potency): 0%
Beside the measured number, compound 4's estimate is 2 percentage points above it; the measured number falls inside the stated range.
By their numbers in this assay, from the lowest: compounds 1, 4, 2 and 3 (each within the scatter of the next).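

In this assay the 2,4,6-trifluorophenyl group on the amine nitrogen in a ring gives a number 2 percentage points lower from compound 3 to compound 4 (within the scatter) and a number 2 percentage points lower from compound 2 to compound 4 (within the scatter) and no change at the digits printed from compound 1 to compound 4 (within the scatter). This position has now taken a fourth aryl group, one carrying three fluorine atoms, and every listed step at it remains within the scatter, so the four compounds cannot be ranked and all stay near the bottom of the scale at the one concentration tested. Nothing measured here offers an explanation for this flat result. Going by these compounds, whether a group of another kind on this nitrogen, such as a benzyl, an acetyl or a longer alkyl chain, would lift the read-out remains open. Also open, on these data alone, is whether any change elsewhere on the shared core would move the number at all.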